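A few compounds are considered here, and "the series" means these few. Any claim that something is new, unique, unknown or untested is made for them only; others in the source may bear on it.

Compound 1 `N#C/C(=C\c1ccc(-c2cccc([N+](=O)[O-])c2)o1)C(=O)NCc1ccccc1Cl` and compound 2 `COc1cccc(CNC(=O)/C(C#N)=C/c2ccc(-c3cccc([N+](=O)[O-])c3)o2)c1` share the same core and differ only in the group on the saturated chain carbon bound to the amide-type nitrogen. In a functional assay on MM1 cells (Homo sapiens) for antiproliferative activity, read by MTT assay, with a stated time of 72 h (a lower number here means a stronger inhibitor, a higher number a weaker inhibitor), compound 1 gives > 10000 nM, which is a limit of the assay rather than a number. In this assay compound 2 likewise gives > 10000 nM, again a limit. The step that the two limits leave unreadable from compound 1 to compound 2 therefore cannot be read in size; the evidence for this is the limit of > 10000 nM in this assay, at which 2 of the 2 values shown sit. Among the measured compounds shown here, compound 2 thus stands at the limit, with the only other value shown sitting there as well.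

Compound 3 `Cc1ccc(CNC(=O)/C(C#N)=C/c2ccc(-c3cccc([N+](=O)[O-])c3)o2)o1` differs from compound 2 by 5-methylfuran-2-yl in place of 3-methoxyphenyl on a saturated chain carbon bound to an amide-type nitrogen. For the measured compounds named here, no measured step shows the effect of this exact change; the one measured step, from compound 1 to compound 2, concerns the same place but is unreadable because of the limit of > 10000 nM in this assay, at which 2 of the 2 values shown sit. Nothing in the data points to a gain, and compound 3 is expected to stay near the limit, with an estimated step that the limit leaves unreadable from compound 2 to compound 3. Compound 3 is estimated at 15000 nM in this assay, within 5000 nM to 50000 nM, most likely reported only as a limit.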

Compound 3, half-maximal inhibitory concentration: > 10000 nM
Compound 3 ended at the assay's limit (the forecaster's own chance of this, stated with the estimate: 80%); the middle value lies beyond the limit too.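

In this assay compound 3 gives > 10000 nM and this is a limit of the assay, not a number. The steps among compound 1, compound 2 and compound 3 therefore cannot be read in size: the limit of > 10000 nM in this assay, at which 3 of the 3 values shown sit. The compounds shown leave open whether any group at this place gives a readable value in this assay at all.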